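Swapping an Ethoxy for an Oxane Ring on the Carbonyl

The source may hold more compounds than are shown below. What is called first, only, known or untested is meant among the compounds shown, and "the series" means these compounds.

Measured so far:
Compound 1, `CCOC(=O)N1CCC(NC(=O)Nc2ccc(C(F)(F)F)c(F)c2)CC1`, gives 5.46 in a physicochemical assay for lipophilicity, read by HPLC, with a stated time of 90 min, tested at 100 uM; on this read-out lower numbers stand for lower lipophilicity and higher numbers for higher lipophilicity.
Compound 2, `O=C(Nc1ccc(OC(F)(F)F)cc1)NC1CCN(C(=O)C2=COCC2)CC1`, gives 3.49.
Compound 3, `O=C(Nc1ccc(OC(F)(F)F)c(F)c1)NC1CCN(C(=O)[C@@H]2CCOC2)CC1`, gives 3.59.

Of the compounds shown here, three built on the shared core have been measured in this assay. Compound 1 stands highest of the three numbers; its nearest neighbour is compound 3, and the gap between them lies beyond the usual scatter, as does the larger gap to compound 2. So compound 1 is clearly the most lipophilic compound measured here, while compounds 2 and 3 sit close together at the lower end.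

Compound 4, `O=C(Nc1ccc(C(F)(F)F)c(F)c1)NC1CCN(C(=O)C2CCOCC2)CC1`, has not yet been measured. It differs from compound 1 in one place: oxan-4-yl in place of ethoxy on a carbonyl carbon. Among the compounds with values here, no pair of measured compounds differs in exactly this way, so the size of the step has to be estimated rather than read off. Compounds 2 and 3 both carry a ring on the carbonyl carbon, and both lie far lower than compound 1, which points towards a drop in this assay rather than a rise. Compound 4 is therefore expected to fall well below compound 1, with an estimated step of a number 1.66 log units lower from compound 1 to compound 4 (beyond the scatter). In this assay compound 4 is estimated at 3.8, within a range from 3.2 to 4.5.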

Compound 4, partition coefficient: 3.52
For compound 4 the middle estimate is 0.28 log units above the measured one; measured number inside the range.
By their numbers in this assay, from the lowest: compounds 2, 4 and 3 (each within the scatter of the next); then compound 1.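

Compounds 2 and 3 differ from compound 1 in more than one place, so they could not single out the group on this carbonyl carbon, whereas compound 4 changes that group alone. In this assay, putting oxan-4-yl in place of ethoxy gives a number 1.94 log units lower from compound 1 to compound 4 (beyond the scatter), a large step that can be tied to this one change at a carbonyl carbon whose other neighbour is an amide-type nitrogen in a ring. The number falls even though the entering group has more heavy atoms, 6 against 3, and brings a six-membered ring, while the count of hydrogen-bond acceptors stays the same, and nothing available here explains why the step goes this way or reaches this size.

This single pair cannot separate the contribution of the ring from that of the ring oxygen, or from the loss of the ethoxy group itself, so a cyclohexyl group on the same carbonyl carbon would be an informative comparison. As far as these compounds go, it also remains open whether an open chain such as 2-methoxyethyl, or an amine such as dimethylamino, would give a step of similar size in this assay.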